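Pyrazolyl for cyclopropylsulfamoyl in the aminopyridine series

The source may report more compounds than this note shows. Statements on the series, on what has been measured and on what is new or still open speak of the compounds shown alone.

Going by the values given here, compound 2 `COc1ccc(-c2cc(-c3ccc(S(=O)(=O)NC4CC4)cc3)cnc2N)cn1` gives 2.7 in a physicochemical assay for lipophilicity, at pH 7.4 (a lower number here means a more polar compound, a higher number a more lipophilic compound), and stands lowest of the two numbers measured so far; its nearest neighbour is compound 1 `COc1ccc(-c2cc(-c3ccc(S(=O)(=O)N(C)C)cc3)cnc2N)cn1`, which gives 2.8, a step of a number 0.10 log units lower from compound 1 to compound 2 (within the scatter) that lies within the scatter. Compound 3 `COc1ccc(-c2cc(-c3ccc(-n4cccn4)cc3)cnc2N)cn1` has not yet been measured. It differs from compound 2 by 1H-pyrazol-1-yl in place of cyclopropylsulfamoyl on an aromatic carbon, placed on an aromatic carbon of a six-membered aromatic ring of carbon only, para to a large group. Among the compounds with values here, the only measured step, from compound 1 to compound 2, changes the group on the sulfonyl sulfur and keeps the sulfonyl itself, so it does not cover the removal of the cyclopropylsulfamoyl and says little about this change. For compound 3 a rise in this assay is expected, estimated as a number 0.70 log units higher from compound 2 to compound 3 (beyond the scatter). The value of compound 3 is estimated at 3.4, with a range from 2.8 to 4.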

Compound 3, distribution coefficient: 3.1
Compound 3: the middle estimate sits 0.30 log units above what was measured, and the stated range covers the measured number.
By their numbers in this assay, from the lowest: compounds 2, 1 and 3 (each within the scatter of the next, the first and the last beyond it).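

At this aromatic carbon, para to a large group, replacing the whole sulfamoyl group moves the reading in this assay in a way the change on the sulfonyl sulfur did not: 1H-pyrazol-1-yl in place of cyclopropylsulfamoyl gives a number 0.40 log units higher from compound 2 to compound 3 (beyond the scatter) in this series. With dimethylsulfamoyl as the reference, the same 1H-pyrazol-1-yl gives a number 0.30 log units higher from compound 1 to compound 3 (within the scatter) and so the shift is small, and its reading as beyond or within the scatter depends on which sulfamoyl group is compared. Nothing available bears on the origin of this shift.

On these data alone, it remains open whether another aromatic ring at this carbon, such as phenyl or 1H-imidazol-1-yl, would read like 1H-pyrazol-1-yl. Also open, as far as these compounds go, is where a carboxylic acid or a morpholine at the same carbon would fall relative to compound 2 and compound 3.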